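Amide Variation on a Shared Core, All at the Limit

A few compounds are considered here, and "the series" means these few. Any claim that something is new, unique, unknown or untested is made for them only; others in the source may bear on it.

Compound 1, `CS(=O)(=O)c1ccc(C(=O)Nc2ccc(Cl)c(-c3nnc4c(Cl)cccn34)c2)c(Cl)c1`: in a functional assay on MCF7 cells (Homo sapiens) for antiproliferative activity, read by MTT assay, with a stated time of 72 h (on this read-out lower numbers stand for stronger inhibition and higher numbers for weaker inhibition), compound 1 gives > 100000 nM, which is a limit of the assay and not a number.
Compound 2, `O=C(Nc1ccc(Cl)c(-c2nnc3c(Cl)cccn23)c1)c1ccccc1`: in this assay compound 2 gives > 100000 nM, again a limit.
Compound 3, `O=C(Nc1ccc(Cl)c(-c2nnc3c(Cl)cccn23)c1)c1ccon1`: in this assay compound 3 gives > 100000 nM, also a limit.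

Compound 3 therefore stands at the limit of > 100000 nM in this assay, at which 3 of the 3 values shown sit, and on the numbers shown it is not separated from either other compound. Among the measured compounds shown here, the only step between measured compounds that differ in one place, a step that the two limits leave unreadable from compound 2 to compound 3, cannot be read, since both of its ends are limits.

Compound 4, `O=C(Nc1ccc(Cl)c(-c2nnc3c(Cl)cccn23)c1)c1ccc(Cl)cc1Cl`, differs from compound 3 by 2,4-dichlorophenyl in place of 1,2-oxazol-3-yl on a carbonyl carbon. For the measured compounds named here, no measured step bears on this change with a readable size. Compound 1, which carries a differently substituted phenyl on a carbonyl carbon, sits at the limit as well. Compound 2, with plain phenyl there, sits at the limit too. No step beyond the scatter is therefore expected in either direction, and compound 4 is expected to remain at the limit. The estimate for compound 4 is 100000 nM, with a range from 30000 nM to 300000 nM. This corresponds to an expected step of a number no higher from compound 3 to compound 4 (the limit leaves the size open).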

Compound 4, half-maximal inhibitory concentration: 78200 nM
The estimate for compound 4 lay 1.3-fold (0.11 log units) above the measured number, and the stated range covers the measured number.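

In this assay, among the compounds shown here, compound 4 gives 78200 nM, the only value shown that is a number and not a limit, so 2,4-dichlorophenyl on this carbonyl carbon brings the series just into the readable range. Against its neighbours the result reads as an at least 1.2-fold lower number from compound 3 to compound 4 (0.10 log units; that floor lies within the scatter), as an at least 1.2-fold lower number from compound 2 to compound 4 (0.10 log units; that floor lies within the scatter), and as an at least 1.2-fold lower number from compound 1 to compound 4 (0.10 log units; that floor lies within the scatter), the last with chloro in place of methylsulfonyl on an aromatic carbon; each is only a floor, so the true size of the change stays open. The other compounds stay at the limit, and the step among them cannot be read: the limit of > 100000 nM in this assay, at which 3 of the 4 values shown sit.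

Going by these compounds, whether a single chlorine on the phenyl would be enough remains open. So does what an amine or a longer chain such as butyl would give on this carbonyl carbon.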